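The source may hold more compounds than are shown below. What is called first, only, known or untested is meant among the compounds shown, and "the series" means these compounds.

Compound 1 `CC1=CC[C@@H]([C@@](C)(O)CCCC(C)(C)NC(=S)NN)CC1` gives 29000 nM in a functional assay on NCI/ADR cells (Homo sapiens) for cytotoxicity, read by sulforhodamine B assay; a higher number here means a weaker inhibitor of growth, a lower number a stronger inhibitor of growth. Compound 2 `COc1ccc(/C=N\NC(=S)NC(C)(C)CCC[C@](C)(O)[C@@H]2CC=C(C)CC2)cc1`, with an aryl-bearing group in place of one nitrogen atom on an amide-type nitrogen, gives 57000 nM in this assay, and the step of a 2.0-fold higher number from compound 1 to compound 2 (0.29 log units; within the scatter) stays within the scatter. Compound 3 `CC1=CC[C@@H]([C@@](C)(O)CCCC(C)(C)NC(=S)N/N=C\c2ccccc2[N+](=O)[O-])CC1` carries 2-nitrophenyl in place of 4-methoxyphenyl on a carbon with a double bond to nitrogen. For compound 3 this assay reports only a limit, > 100000 nM, so compound 3 stands at the open-ended edge of the numbers shown. The step of an at least 1.7-fold higher number from compound 2 to compound 3 (0.24 log units; that floor lies within the scatter) has a floor that lies within the scatter.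

Compound 4 `CC1=CC[C@@H]([C@@](C)(O)CCCC(C)(C)NC(=S)N/N=C\c2ccccc2Cl)CC1` differs from compound 3 by chloro in place of nitro on an aromatic carbon, a chloro in place of nitro on an aromatic carbon. Among the measured compounds shown here, no measured step covers this swap; the nearest is an at least 1.7-fold higher number from compound 2 to compound 3 (0.24 log units; that floor lies within the scatter), an aryl change that ended at the limit of > 100000 nM in this assay, at which 1 of the 3 values shown sits. Compound 4 is therefore expected to move by a number no higher from compound 3 to compound 4 (the limit leaves the size open), staying near the limit. Compound 4 is estimated at 100000 nM, between 40000 nM and 250000 nM.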

Compound 4, concentration for total growth inhibition: > 100000 nM
Compound 4 ended at the assay's limit (the forecaster's own chance of this, stated with the estimate: 50%); the middle value sits exactly at the limit.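

In this assay compound 4 gives > 100000 nM, again a limit, so the step from compound 3 to compound 4 cannot be read, and neither nitro nor chloro on this aromatic carbon gives a value inside the readable range: the limit of > 100000 nM in this assay, at which 2 of the 4 values shown sit.

What is new is a step beyond the scatter for an aryl-bearing group on the amide-type nitrogen: an at least 3.4-fold higher number from compound 1 to compound 4 (0.53 log units; beyond the scatter), where the 4-methoxyphenyl group gave a 2.0-fold higher number from compound 1 to compound 2 (0.29 log units; within the scatter). The comparison with 4-methoxyphenyl itself stays less firm, with an at least 1.7-fold higher number from compound 2 to compound 4 (0.24 log units; that floor lies within the scatter).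

On these data alone, how far compound 3 and compound 4 lie past the limit remains open. So does whether an amine or a fluoro on the same aromatic carbon would give a readable value.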